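Thromboxane synthase inhibitors: aryl exchange at the acetal oxygen

This account rests on a few compounds, and the source may have more. Where it says the series, first, only, none or still open, it means among the compounds named here.

Measured compounds:
compound 1 `O=C(O)CC/C=C\CC1COC(c2ccc3ccccc3c2)OC1c1cccnc1` gives 50 nM
compound 2 `O=C(O)CC/C=C\CC1COC(c2cccc3ccccc23)OC1c1cccnc1` gives 40 nM
compound 3 `CSc1ccc(OC(C)(C)C2OCC(C/C=C\CCC(=O)O)C(c3cccnc3)O2)c([N+](=O)[O-])c1` gives 22 nM

All three values come from an assay for inhibition of Thromboxane-A synthase (Homo sapiens), using microsomes; on this read-out lower numbers stand for stronger inhibition and higher numbers for weaker inhibition. Compound 3 shows the lowest number of the three; against compound 2 the gap stays within the scatter, against compound 1 it lies beyond it. Among the compounds with values here, the only single-point step among the measured compounds is a 1.3-fold lower number from compound 1 to compound 2 (0.10 log units; within the scatter), which swaps one naphthyl isomer for the other on a saturated ring carbon and stays within the scatter.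

Compound 4 `COc1ccccc1OC(C)(C)C1OCC(C/C=C\CCC(=O)O)C(c2cccnc2)O1` is derived from compound 3 by a group of 8 heavy atoms (7 carbon, 1 oxygen; one six-membered aromatic ring of carbon only) in place of a group of 11 heavy atoms (7 carbon, 1 nitrogen, 2 oxygen, 1 sulfur; one six-membered aromatic ring of carbon only), on an oxygen on a saturated carbon. Within the data shown here, the measured step concerns a different place and a different kind of exchange, so no measured step bears on the change from compound 3 to compound 4; the effect of the aryl group on the oxygen is untested in this set. With the shared core of compound 3 kept intact, the expectation is a step of about a 1.6-fold higher number from compound 3 to compound 4 (0.20 log units; within the scatter) in this assay, not clearly beyond the scatter in either direction, with a wide range to reflect the lack of a comparable step. Compound 4 is therefore estimated at 35 nM, with a range from 10 nM to 120 nM.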

Compound 4, half-maximal inhibitory concentration: 60 nM
Compound 4: middle estimate off by 1.7-fold (0.23 log units), on the low side; the measured number falls inside the stated range.
By their numbers in this assay, from the lowest: compounds 3, 2, 1 and 4 (each within the scatter of the next, the first and the last beyond it).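

In this assay, within the data shown here, the aryl-bearing group on the oxygen on a saturated carbon is a place where the exchange registers: a 2.7-fold higher number from compound 3 to compound 4 (0.44 log units; beyond the scatter) is the first step to lie beyond the scatter, while the only earlier step, the exchange of one naphthyl isomer for the other, stayed within it. Putting 2-methoxyphenyl in place of the group of 11 heavy atoms, with the shared core kept intact, therefore costs inhibition, though the step is modest in size and is a single observation at this place. Nothing shown here accounts for the direction or size of this step.

The two groups differ in several features at once, with sulfur and nitrogen present only in the group that leaves, and a single exchange cannot show which feature carries the step. Open also is how the read-out responds to an unsubstituted phenyl, or to an amine or a carboxylic acid on the aromatic ring, at this same place on the oxygen.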